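Phenyl replacements for the pyridinyl group on the thiophene series

The source may report more compounds than this note shows. Statements on the series, on what has been measured and on what is new or still open speak of the compounds shown alone.

Of the compounds shown here, three of the shared core have been measured in a functional assay on MOLT-4 cells (Homo sapiens) for antiproliferative activity; a lower number here means a stronger inhibitor, a higher number a weaker inhibitor. Compound 1 `COc1ccc(-c2cc(N)c(C(=O)c3cc(OC)c(OC)c(OC)c3)s2)cc1OC` gives 20 nM, compound 2 `COc1cc(C(=O)c2sc(-c3ccncc3)cc2N)cc(OC)c1OC` gives 88 nM, and compound 3 `COc1ccc(-c2cc(N)c(C(=O)c3cc(OC)c(OC)c(OC)c3)s2)cc1` gives 18 nM. Compound 2 therefore carries the highest number of the three: a 4.4-fold higher number from compound 1 to compound 2 (0.64 log units; beyond the scatter), and a 4.9-fold lower number from compound 2 to compound 3 (0.69 log units; beyond the scatter). Between compound 1 and compound 3 there is a 1.1-fold lower number from compound 1 to compound 3 (0.05 log units; within the scatter).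

Compound 4 `COc1cc(C(=O)c2sc(-c3ccc(C(F)(F)F)cc3)cc2N)cc(OC)c1OC` is not yet measured. It differs from compound 2 in one place: 4-(trifluoromethyl)phenyl in place of pyridin-4-yl on an aromatic carbon. The measured steps that bear on this are the two in which pyridin-4-yl stands against a carbon-only ring, a 4.9-fold lower number from compound 2 to compound 3 (0.69 log units; beyond the scatter) and a 4.4-fold higher number from compound 1 to compound 2 (0.64 log units; beyond the scatter), both modest and beyond the scatter, both in favour of the carbon-only ring. Among the compounds with values here, the entering 4-(trifluoromethyl)phenyl has no direct precedent, so the expected step is taken from those two with a wider range. A lower number is expected for compound 4, a 2.9-fold lower number from compound 2 to compound 4 (0.47 log units; beyond the scatter), giving an estimate of 30 nM with a range from 10 nM to 100 nM.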

Compound 4, half-maximal inhibitory concentration: 250 nM
Compound 4: middle estimate off by 8.3-fold (0.92 log units), on the low side; measured number outside the range, above it.
By their numbers in this assay, from the lowest: compounds 3 and 1 (each within the scatter of the next); then compound 2; then compound 4.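

In this assay, a carbon-only ring at this position does not by itself give a lower number than pyridin-4-yl (a 2.8-fold higher number from compound 2 to compound 4 (0.45 log units; beyond the scatter)), so compound 2 now sits between compound 4 and the methoxy-bearing compounds 1 and 3. The group carried by the carbon-only ring decides the outcome here: trifluoromethyl in place of methoxy gives a large step (a 14-fold higher number from compound 3 to compound 4 (1.14 log units; beyond the scatter)), and the change from 3,4-dimethoxyphenyl is also large (a 13-fold higher number from compound 1 to compound 4 (1.10 log units; beyond the scatter)). No measured evidence on these groups is available to explain this order.

As far as these compounds go, what plain phenyl gives at this position stays open, and with it whether trifluoromethyl raises the number or methoxy lowers it. Also open, from the compounds shown here alone, is where an amine or a carboxylic acid on that ring would fall relative to methoxy and trifluoromethyl.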